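The source may hold more compounds than are shown below. What is called first, only, known or untested is meant among the compounds shown, and "the series" means these compounds.

Measured in an assay on CHO cells for displacement of a labelled ligand from histamine receptor H3 (Macaca mulatta), read by scintillation counting, with a stated time of 1 h; a lower number here means a stronger inhibitor, a higher number a weaker inhibitor:

Compound 1 `CC(=O)N(C)C1CCN(C(=O)Nc2ccc(N3CCC(N4CCCC4C)C3)cc2)C1` gives 35.5 nM.
Compound 2 `CC(=O)N(C)C1CCN(C(=O)Nc2ccc(N3CCC(N4CCCC4C)C3)c(C)c2)C1` gives 89.7 nM.
Compound 3 `CC1CCCN1C1CCN(c2ccc(NC(=O)NCc3cc(Cl)cc(Cl)c3)cc2)C1` gives 7.1 nM.

Compound 1 and compound 3 share a core and differ at the carbonyl carbon: (3,5-dichlorobenzyl)amino in place of 3-(acetyl(methyl)amino)pyrrolidin-1-yl on a carbonyl carbon. That change gives a 5.0-fold lower number from compound 1 to compound 3 (0.70 log units; beyond the scatter), and compound 3 has the lowest number of the three, with its steps to compound 1 and compound 2 both beyond the scatter.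

Compound 1 and compound 2 differ by methyl in place of hydrogen on an aromatic carbon. The step is a 2.5-fold higher number from compound 1 to compound 2 (0.40 log units; beyond the scatter), a modest rise in the number.

Compound 4 `Cc1cc(NC(=O)NCc2cc(Cl)cc(Cl)c2)ccc1N1CCC(N2CCCC2C)C1` is not yet measured in this assay. It differs from compound 3 by methyl in place of hydrogen on an aromatic carbon. This is the same change as from compound 1 to compound 2; the place is described in the same words for both pairs. The two cores differ as described under the change from compound 1 to compound 3.

Resting on a single earlier instance, a 2.5-fold higher number from compound 1 to compound 2 (0.40 log units; beyond the scatter), the step from compound 3 to compound 4 is expected to be a 2.5-fold higher number from compound 3 to compound 4 (0.40 log units; beyond the scatter). For compound 4 the estimate in this assay is 18 nM, with a likely range from 7 nM to 45 nM.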

Compound 4, inhibition constant: 28.8 nM
Compound 4: the middle estimate sits 1.6-fold (0.20 log units) below what was measured; the measured number falls inside the stated range.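

In this assay methyl in place of hydrogen on an aromatic carbon again gives a higher number, here a 4.1-fold higher number from compound 3 to compound 4 (0.61 log units; beyond the scatter) and the size of the step carries across the two cores: the same change on two cores in this assay, a 2.5-fold higher number (0.40 log units; beyond the scatter) from compound 1 to compound 2 and a 4.1-fold higher number (0.61 log units; beyond the scatter) from compound 3 to compound 4, 1.6-fold (0.21 log units) apart, within the scatter of two such steps.
The exchange on the carbonyl carbon, (3,5-dichlorobenzyl)amino in place of 3-(acetyl(methyl)amino)pyrrolidin-1-yl, also holds when the methyl is present, with a 3.1-fold lower number from compound 2 to compound 4 (0.49 log units; beyond the scatter) and agreement between its two instances: the same change on two cores in this assay, a 5.0-fold lower number (0.70 log units; beyond the scatter) from compound 1 to compound 3 and a 3.1-fold lower number (0.49 log units; beyond the scatter) from compound 2 to compound 4, 1.6-fold (0.21 log units) apart, within the scatter of two such steps.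
Across these four compounds the two changes therefore behave as separable steps, but each rests on only one pair of cores, so this does not show that either step would hold on a different core or in a different assay, and it gives no reason for the rise in the number.

The compounds shown leave open whether a fluorine, a chlorine, a methoxy or an ethyl at the same aromatic carbon would follow the methyl step. They also leave open whether the step would persist with a carboxylic acid or a simple amine in place of the groups on the carbonyl carbon.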